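But-1-yn-1-yl to pent-1-yn-1-yl: compound 3 to compound 4

The source may report more compounds than this note shows. Statements on the series, on what has been measured and on what is new or still open speak of the compounds shown alone.

Measured in a functional assay on MIA PaCa-2 cells (Homo sapiens) for antiproliferative activity; on this read-out higher numbers stand for an effect only at larger amounts of compound and lower numbers for an effect already at smaller amounts
- compound 1 `C#CCNC(=O)c1cccc2c1cc(C)n2-c1nc2c(c(NCc3ccccc3)n1)CCCC2` gives 470 nM
- compound 2 `Cc1cc2c(C(=O)NCC#N)cccc2n1-c1nc2c(c(NCc3ccccc3)n1)CCCC2` gives 468 nM
- compound 3 `CCC#CC(=O)Nc1cccc2c1cc(C)n2-c1nc2c(c(NCc3ccccc3)n1)CCCC2` gives 463 nM

Compound 3 stands at 463 nM in this assay and sits within the scatter of compound 1 and compound 2. The next analogue is compound 4 `CCCC#CC(=O)Nc1cccc2c1cc(C)n2-c1nc2c(c(NCc3ccccc3)n1)CCCC2` and its difference is methyl in place of hydrogen on a saturated chain carbon, two bonds along the chain from a triple-bonded carbon with methyl in place of hydrogen on a saturated chain carbon, two bonds along the chain from a triple-bonded carbon. The same difference reads but-1-yn-1-yl to pent-1-yn-1-yl. For the measured compounds named here, no measured step makes this exact change. The closest evidence is a 1.0-fold lower number from compound 1 to compound 3 (0.01 log units; within the scatter) for a swap of a whole group on an aromatic carbon, and the other two steps are a 1.0-fold lower number from compound 1 to compound 2 (0.00 log units; within the scatter) and a 1.0-fold lower number from compound 2 to compound 3 (0.00 log units; within the scatter) in this small set. All three stay within the scatter, so no step beyond it is expected here. The expected step is a 1.0-fold lower number from compound 3 to compound 4 (0.01 log units; within the scatter) on this evidence. For compound 4 the estimate is 450 nM with an expected range from 240 nM to 850 nM in this read-out.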

Compound 4, half-maximal effective concentration: 1570 nM
The estimate for compound 4 lay 3.5-fold (0.54 log units) below the measured number; the whole stated range lies below it.
By their numbers in this assay, from the lowest: compounds 3, 2 and 1 (each within the scatter of the next); then compound 4.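

In this assay, for the compounds shown here, the single added methyl on a saturated chain carbon, two bonds along the chain from a triple-bonded carbon, gives a 3.4-fold higher number from compound 3 to compound 4 (0.53 log units; beyond the scatter), the first step in this set beyond the scatter. The group swaps among compound 1, compound 2 and compound 3 all stayed within the scatter, yet the extension from but-1-yn-1-yl to pent-1-yn-1-yl does not, and compound 4 also stands apart in a 3.4-fold higher number from compound 2 to compound 4 (0.53 log units; beyond the scatter) and a 3.3-fold higher number from compound 1 to compound 4 (0.52 log units; beyond the scatter). Nothing available explains this step.

On these data alone, whether a longer chain such as hex-1-yn-1-yl continues the trend from one step remains open. Also open, as far as these compounds go, is how the number responds to an amine or a carboxylic acid in place of the added methyl.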